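Swapping a Furan Ring for Methoxy on the Shared Core

This account rests on a few compounds, and the source may have more. Where it says the series, first, only, none or still open, it means among the compounds named here.

Compound 1, `CNc1ncnc2[nH]cc(Sc3cccs3)c12`, gives 17600 nM in a functional assay on HeLa S3 cells (Homo sapiens) for cytotoxicity, read by XTT assay, with a stated time of 6 days; on this read-out higher numbers stand for weaker inhibition and lower numbers for stronger inhibition.
Compound 2, `Nc1ncnc2[nH]cc(Sc3cccs3)c12`, gives 17900 nM.
Compound 3, `c1coc(-c2ncnc3[nH]cc(Sc4cccs4)c23)c1`, gives 8490 nM.

Among the three measured compounds, compound 3 has the lowest number. The step of a 2.1-fold lower number from compound 1 to compound 3 (0.32 log units; beyond the scatter) and the step of a 2.1-fold lower number from compound 2 to compound 3 (0.32 log units; beyond the scatter) are both beyond the scatter, though modest. Compound 1 and compound 2 lie within the scatter of each other, as the step of a 1.0-fold higher number from compound 1 to compound 2 (0.01 log units; within the scatter) shows.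

Compound 4, `COc1ncnc2[nH]cc(Sc3cccs3)c12`, is not yet measured. It differs from compound 3 in one place: methoxy in place of furan-2-yl on an aromatic carbon. The two steps that bear on this are those from compound 1 and compound 2 to compound 3, where a small group gave way to furan-2-yl and the number fell modestly. Going by the values given here, in compound 4 the furan ring leaves again and a small group enters, so a modest rise back toward the level of compound 1 and compound 2 is the natural expectation, with the caution that methoxy itself has no measured counterpart here. Compound 4 is therefore expected to give 15000 nM in this assay, within a range from 6000 nM to 40000 nM. The expected step of a 1.8-fold higher number from compound 3 to compound 4 (0.25 log units; within the scatter) is small, only just beyond the scatter.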

Compound 4, half-maximal inhibitory concentration: 23900 nM
Compound 4: the middle estimate sits 1.6-fold (0.20 log units) below what was measured, within the range that was stated.
By their numbers in this assay, from the lowest: compound 3; then compounds 1, 2 and 4 (each within the scatter of the next).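

In this assay replacing furan-2-yl with methoxy on this aromatic carbon of the shared core gives a 2.8-fold higher number from compound 3 to compound 4 (0.45 log units; beyond the scatter) and so removes the lower number of compound 3, even though the two groups have the same counts of hydrogen-bond donors and acceptors. What differs between them in this comparison is the ring and the number of heavy atoms. Methoxy also cannot be told apart from the amino and methylamino groups here, since a 1.3-fold higher number from compound 2 to compound 4 (0.13 log units; within the scatter) and a 1.4-fold higher number from compound 1 to compound 4 (0.13 log units; within the scatter) are both within the scatter, which leaves furan-2-yl as the only group at this place that stands apart, and only modestly. Nothing available explains why the furan-2-yl compound differs from the other three.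

The compounds shown cannot separate the effect of having a ring at this place from the effect of having a larger group, and a phenyl ring or a thiophene ring would bear on that question. A longer chain such as ethoxy or propoxy would also show whether size without a ring moves the number at all.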